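Isobutyl in Place of Cyclohexyl on the Shared Core

The compounds below may be only part of what the source reports. "The series", "measured", "known", "first", "only" and "open" are said of these compounds alone.

Measured in a functional assay on CHO-K1 cells (Cricetulus griseus) for inhibition, read by MTT assay, with a stated time of 72 h; a higher number here means a weaker inhibitor, a lower number a stronger inhibitor:
- Compound 1 `CCCNC(=C\C(=O)/C=C/c1ccc(O)c(OC)c1)/C=C/c1ccc(O)c(OC)c1`: > 25000 nM, a limit of the assay
- Compound 2 `C=CCNC(=C\C(=O)/C=C/c1ccc(O)c(OC)c1)/C=C/c1ccc(O)c(OC)c1`: 7400 nM
- Compound 3 `COc1cc(/C=C/C(=O)/C=C(/C=C/c2ccc(O)c(OC)c2)NC2CCCCC2)ccc1O`: 24700 nM

Of the two actual numbers in this assay, compound 3 holds the higher, and compound 2 is its nearest neighbour. Compound 1 has only a limit and no number.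

Compound 4 `COc1cc(/C=C/C(=O)/C=C(/C=C/c2ccc(O)c(OC)c2)NCC(C)C)ccc1O` differs from compound 3 by isobutyl in place of cyclohexyl on an amine nitrogen. Neither group has been compared directly with the other. The step from allyl to cyclohexyl gave a 3.3-fold higher number from compound 2 to compound 3 (0.52 log units; beyond the scatter), and the step from propyl to allyl gave an at least 3.3-fold lower number from compound 1 to compound 2 (0.52 log units; beyond the scatter). Both steps involve the allyl of compound 2, which compound 4 lacks. The closer comparison is propyl against cyclohexyl, which gave an at least 1.0-fold lower number from compound 1 to compound 3 (0.00 log units; that floor lies within the scatter). With that step as the guide, no change beyond the scatter is expected, and the expected result is a 1.1-fold lower number from compound 3 to compound 4 (0.05 log units; within the scatter). For compound 4 the estimated value is 22000 nM, with an expected range from 11000 nM to 45000 nM.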

Compound 4, half-maximal inhibitory concentration: > 25000 nM
Compound 4: only a limit was reported; the forecaster's own chance of this, stated with the estimate: 45%; middle value at least 1.1-fold (0.05 log units) away from the limit.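

In this assay, the change from cyclohexyl to isobutyl on the amine nitrogen gave an at least 1.0-fold higher number from compound 3 to compound 4 (0.00 log units; that floor lies within the scatter), so these two groups cannot be told apart at this position. Against the allyl group, the change gave an at least 3.3-fold higher number from compound 2 to compound 4 (0.52 log units; beyond the scatter), which leaves compound 2 as the only compound shown whose number lies clearly below those of the other three. The result for compound 4 is a limit of the assay, and compound 4 shares it with one other compound: the limit of > 25000 nM in this assay, at which 2 of the 4 values shown sit.

The step from compound 1 to compound 4 cannot be read, as both values are limits. Still open, on these data alone, is whether the lower number of compound 2 needs the double bond of the allyl group, and whether a propargyl group or a 2-hydroxyethyl group on this nitrogen would keep it.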